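The source may report more compounds than this note shows. Statements on the series, on what has been measured and on what is new or still open speak of the compounds shown alone.

Measured in a functional assay on MCF7 cells (Homo sapiens) for antiproliferative activity, read by MTT assay, with a stated time of 48 h; on this read-out higher numbers stand for weaker inhibition and lower numbers for stronger inhibition:

Compound 1 `CC(C)=CCC[C@]1(C)/C=C/[C@@H](OC(=O)C=C(C)C)[C@](C)(O)/C=C/C(=O)/C(CN(C(C)C)C(C)C)=C\C1`: 780 nM
Compound 2 `CC(C)=CCC[C@]1(C)/C=C/[C@@H](OC(=O)C=C(C)C)[C@](C)(O)/C=C/C(=O)/C(CN2CCCC2)=C\C1`: 220 nM
Compound 3 `CC(C)=CCC[C@]1(C)/C=C/[C@@H](OC(=O)C=C(C)C)[C@](C)(O)/C=C/C(=O)/C(CN2CCN(C)CC2)=C\C1`: 550 nM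

Compound 3, at 550 nM, cannot be told apart from compound 1, the step being a 1.4-fold lower number from compound 1 to compound 3 (0.15 log units; within the scatter). Compound 2 stands clearly apart from both, and its step to the piperazine compound is a 2.5-fold higher number from compound 2 to compound 3 (0.40 log units; beyond the scatter).

Compound 4 `CC(C)=CCC[C@]1(C)/C=C/[C@@H](OC(=O)C=C(C)C)[C@](C)(O)/C=C/C(=O)/C(Cn2cc(CO)nn2)=C\C1` has not yet been measured. It keeps the shared core and differs from compound 3 in one group: 4-(hydroxymethyl)-1H-1,2,3-triazol-1-yl in place of 4-methylpiperazin-1-yl on a saturated chain carbon bound to a double-bonded ring carbon. Here 4-(hydroxymethyl)-1H-1,2,3-triazol-1-yl stands in place of 4-methylpiperazin-1-yl on a saturated chain carbon bound to a double-bonded ring carbon.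

The measured steps that bear on this change are the exchanges at the same place, and the largest is a 3.5-fold lower number from compound 1 to compound 2 (0.55 log units; beyond the scatter). The other two are a 1.4-fold lower number from compound 1 to compound 3 (0.15 log units; within the scatter) and a 2.5-fold higher number from compound 2 to compound 3 (0.40 log units; beyond the scatter), so none exceeds a modest size. For the measured compounds named here, none of the three compounds carries an aromatic ring at this place, so the data offer no direct precedent and only a loose guide. No direction can be settled from them, and no step beyond the scatter is expected in this assay, though a modest move either way would not surprise. The expected step is a 1.1-fold higher number from compound 3 to compound 4 (0.04 log units; within the scatter). For compound 4 the estimated value is 600 nM, within an expected range from 200 nM to 1800 nM.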

Compound 4, half-maximal inhibitory concentration: 2930 nM
For compound 4 the middle estimate is 4.9-fold (0.69 log units) below the measured one; the measured number lies above the stated range.
By their numbers in this assay, from the lowest: compound 2; then compounds 3 and 1 (each within the scatter of the next); then compound 4.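

In this assay, placing 4-(hydroxymethyl)-1H-1,2,3-triazol-1-yl on the saturated chain carbon bound to a double-bonded ring carbon gives a 5.3-fold higher number from compound 3 to compound 4 (0.73 log units; beyond the scatter) along with a 3.8-fold higher number from compound 1 to compound 4 (0.57 log units; beyond the scatter) and a 13-fold higher number from compound 2 to compound 4 (1.12 log units; beyond the scatter) in the same direction, the last being the largest step yet seen at this place. The position therefore tolerates less than the three amines suggested, for compound 4 is the weakest of the four, and the group exchanged here holds as many heavy atoms as 4-methylpiperazin-1-yl, so that count does not separate them. The change swaps a six-membered non-aromatic ring for a five-membered aromatic one and also adds a hydrogen-bond donor, and no measurement is at hand to tie the loss to any property of either group.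

The compounds shown leave open whether the loss belongs to the triazole ring itself or to its hydroxymethyl substituent, which a plain 1H-1,2,3-triazol-1-yl group would help to separate. They also leave open whether an amine carried on the triazole, such as an aminomethyl group in place of the hydroxymethyl, or a longer chain there, would behave like compound 4 or move back towards the amines.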